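This account rests on a few compounds, and the source may have more. Where it says the series, first, only, none or still open, it means among the compounds named here.

Measured compounds:
- compound 1 `N#Cc1c(Nc2ccc(Cl)cc2)nc(SCc2cn(Cc3ccccc3Cl)nn2)nc1-c1ccccc1`: in a functional assay on ECa-109 cells (Homo sapiens) for inhibition, read by MTT assay, with a stated time of 72 h (on this read-out higher numbers stand for weaker inhibition and lower numbers for stronger inhibition), compound 1 gives 1420 nM
- compound 2 `COc1ccccc1Nc1nc(SCc2cn(Cc3ccccc3Cl)nn2)nc(-c2ccccc2)c1C#N`: in this assay compound 2 gives 9670 nM
- compound 3 `Cc1cccc(Nc2nc(SCc3cn(Cc4ccccc4Cl)nn3)nc(-c3ccccc3)c2C#N)c1`: in this assay compound 3 gives 15600 nM

Compound 3 carries the highest number of the three, but the step of a 1.6-fold higher number from compound 2 to compound 3 (0.21 log units; within the scatter) is within the scatter, so compounds 2 and 3 are not separated; only compound 1 stands clearly apart, with an 11-fold higher number from compound 1 to compound 3 (1.04 log units; beyond the scatter) and a 6.8-fold higher number from compound 1 to compound 2 (0.83 log units; beyond the scatter) both beyond the scatter.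

Compound 4 `N#Cc1c(Nc2ccc(F)cc2)nc(SCc2cn(Cc3ccccc3Cl)nn2)nc1-c1ccccc1` is not yet measured. It differs from compound 3 in one place: 4-fluorophenyl in place of 3-methylphenyl on a nitrogen on an aromatic ring. The step that bears on this is an 11-fold higher number from compound 1 to compound 3 (1.04 log units; beyond the scatter), in which a 4-chlorophenyl group on the same nitrogen was exchanged for 3-methylphenyl and the number rose sharply. From the compounds shown here alone, compound 4 returns a halogen to that same ring position, so the expectation is a step back downward, of a size comparable to that earlier step, though the fluorine case is untested and some of the gain may not carry over. For compound 4 the expected step is a 6.2-fold lower number from compound 3 to compound 4 (0.80 log units; beyond the scatter). The estimate for compound 4 in this assay is 2500 nM, with a range from 900 nM to 7000 nM.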

Compound 4, half-maximal inhibitory concentration: 25800 nM
The estimate for compound 4 lay 10-fold (1.01 log units) below the measured number, and the stated range ends below it.
By their numbers in this assay, from the lowest: compound 1; then compounds 2, 3 and 4 (each within the scatter of the next, the first and the last beyond it).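

In this assay, fluoro in place of chloro on an aromatic carbon is a large change for so small an exchange (an 18-fold higher number from compound 1 to compound 4 (1.26 log units; beyond the scatter)), so a halogen on this ring does not by itself carry the low number of compound 1; among the four aryl groups on this nitrogen, only 4-chlorophenyl stands apart. 4-Fluorophenyl is not separated from 3-methylphenyl (a 1.7-fold higher number from compound 3 to compound 4 (0.22 log units; within the scatter)), while it does stand apart from 2-methoxyphenyl (a 2.7-fold higher number from compound 2 to compound 4 (0.43 log units; beyond the scatter)). No measurement on any property of these groups accompanies the result, so the gap between chloro and fluoro stays unexplained.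

Open, from the compounds shown here alone, is whether the low number extends to 4-bromophenyl or 4-methylphenyl or stays with 4-chlorophenyl alone. Also open, going by these compounds, is how a saturated amine such as morpholine would read in place of the arylamino group.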